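A few compounds are considered here, and "the series" means these few. Any claim that something is new, unique, unknown or untested is made for them only; others in the source may bear on it.

Measured so far:
- compound 1 `Cc1cc(C#N)cc(C)c1Oc1ccc(N)c(Nc2ccc(C#N)cc2)n1`: > 100000 nM, a limit
- compound 2 `CC(=O)/C=C/c1cc(C)c(Oc2ccc([N+](=O)[O-])c(Nc3ccc(C#N)cc3)n2)c(C)c1`: > 47900 nM, a limit
- compound 3 `Cc1cc(/C=C/C#N)cc(C)c1Oc1ccc([N+](=O)[O-])c(Nc2ccc(C#N)cc2)n1`: > 100000 nM, a limit

In an ADME assay on MT2 cells (Homo sapiens) for cytotoxicity, read by XTT assay, with a stated time of 4 days (a higher number here means that more compound is tolerated, a lower number that less compound is tolerated), compound 1 gives > 100000 nM, which is a limit and not a number. Compound 1 therefore sits at the limit of > 100000 nM in this assay, at which 2 of the 3 values shown sit. Compound 2 sits at the limit of > 47900 nM in this assay, at which 1 of the 3 values shown sits.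

Compound 4 `CC(=O)CCc1cc(C)c(Oc2ccc(N)c(Nc3ccc(C#N)cc3)n2)c(C)c1` carries 2-acetylethyl in place of cyano on an aromatic carbon of the core of compound 1, meta to two methyl groups and para to a large group: 2-acetylethyl in place of cyano on an aromatic carbon.

Within the data shown here, the only measured step that bears on this is a step that the two limits leave unreadable from compound 2 to compound 3. It involves the same two groups, but on a chain, and gives no size. Among the measured compounds shown here, no measured step therefore sizes the change in this assay. The expectation leans on compound 2, which also carries an acetyl group and has a value of > 47900 nM, again a limit. With compound 1 at a limit, only a move towards less compound tolerated could be read, and a modest one is expected. The estimated change is an at least 2.0-fold lower number from compound 1 to compound 4 (0.30 log units; that floor lies within the scatter). For compound 4 the expected value is 50000 nM, with an estimated range of 12000 nM to 100000 nM.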

Compound 4, half-maximal cytotoxic concentration: 18400 nM
Beside the measured number, compound 4's estimate is 2.7-fold (0.43 log units) above it, and the stated range covers the measured number.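

In this assay, 2-acetylethyl in place of the nitrile on the aromatic carbon, meta to two methyl groups and para to a large group, gives an at least 5.4-fold lower number from compound 1 to compound 4 (0.73 log units; beyond the scatter), which shows that a change at this position can lower the tolerated concentration. The size is a minimum, since compound 1 gives > 100000 nM, a limit, and the step from compound 2 to compound 3 cannot be read, so this is the only step shown with a readable size. No measured property shown accounts for this step.

The compounds shown leave open whether the lower number goes with the carbonyl or with the chain itself; a butyl or 2-cyanoethyl group on the same aromatic carbon would separate the two. Also open, as far as these compounds go, is how a carboxylic acid or an amine at the end of the chain would read in this assay.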